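Replacing 3-methylthiophen-2-yl in compound 2

A few compounds are considered here, and "the series" means these few. Any claim that something is new, unique, unknown or untested is made for them only; others in the source may bear on it.

Measured in a functional assay on HCT-15 cells (Homo sapiens) for cytotoxicity, read by ELISA, with a stated time of 4 days (a higher number here means a weaker inhibitor, a lower number a stronger inhibitor), so far:
Compound 1 (`Cc1ccsc1-c1cc(-c2ccoc2)cc(-c2ccc(Cl)cc2)n1`) gives 2990 nM
Compound 2 (`Cc1ccsc1-c1cc(-c2ccc(Cl)o2)cc(-c2ccc(Cl)cc2)n1`) gives 30300 nM
Compound 3 (`Cc1ccsc1-c1cc(-c2ccc(Cl)o2)cc(-c2cccnc2)n1`) gives > 50000 nM

Compound 2 holds the higher of the two actual numbers. Compound 3 stands at > 50000 nM as a limit and not a number.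

Compound 4 (`Clc1ccc(-c2cc(-c3ccc(Cl)o3)cc(-c3ccc(Cl)s3)n2)cc1`) has 5-chlorothiophen-2-yl in place of 3-methylthiophen-2-yl (5-chlorothiophen-2-yl in place of 3-methylthiophen-2-yl on an aromatic carbon). Neither measured step touches this place. The large step of a 10-fold higher number from compound 1 to compound 2 (1.01 log units; beyond the scatter) involves the furan group, and the step of an at least 1.6-fold higher number from compound 2 to compound 3 (0.21 log units; that floor lies within the scatter) involves the 4-chlorophenyl group. With no measured guide, compound 2 at 30300 nM remains the anchor, and no step beyond the scatter is expected in this assay here. The expected step is a 1.1-fold lower number from compound 2 to compound 4 (0.03 log units; within the scatter) at most within the scatter. Compound 4 is estimated at 28000 nM with a range from 10000 nM to 50000 nM in this assay.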

Compound 4, half-maximal inhibitory concentration: 25300 nM
For compound 4 the middle estimate is 1.1-fold (0.04 log units) above the measured one; low and high end bracket the measured number.
By their numbers in this assay, from the lowest: compound 1; then compounds 4 and 2 (each within the scatter of the next). At a limit, above all of these: compound 3.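

For the compounds shown here, exchanging 3-methylthiophen-2-yl for 5-chlorothiophen-2-yl on the carbon next to the ring nitrogen gives a 1.2-fold lower number from compound 2 to compound 4 (0.08 log units; within the scatter) in this assay, the first reading at this position. With 4-chlorophenyl and 5-chlorofuran-2-yl held fixed, the two thiophene groups cannot be told apart in this assay. No measured property of these groups bears on this result.

From the compounds shown here alone, it remains open whether this exchange would read the same with the furan-3-yl group of compound 1 in place. Also open, going by these compounds, is what an amine or a carboxylic acid on this carbon would give.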